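From a pyrrolidine to an aniline on the shared core

The source may hold more compounds than are shown below. What is called first, only, known or untested is meant among the compounds shown, and "the series" means these compounds.

Three compounds with one shared core were tested in an assay for inhibition of Indoleamine 2,3-dioxygenase 1 (Homo sapiens), with stated times of 10 min and 60 min, tested at 10 uM; a higher number here means a stronger effect of the compound at the concentration tested, a lower number a weaker effect. Compound 1 `FC(F)(F)c1cc(NC[C@H]2CCCN2)c2cn[nH]c2c1` gives 34%. Compound 2 `O=[N+]([O-])c1cc(Cl)ccc1CNc1cc(C(F)(F)F)cc2[nH]ncc12` gives 50%, and compound 3 `O=[N+]([O-])c1ccccc1CNc1cc(Br)cc2[nH]ncc12` gives 67%. Compound 1 therefore stands lowest of the three: its gap to compound 2, the nearest, lies beyond the usual scatter, and its gap to compound 3, the furthest, is wider still. Compound 4 `Nc1cccc(CNc2cc(C(F)(F)F)cc3[nH]ncc23)c1` has not yet been measured. It differs from compound 1 in one place: 3-aminophenyl in place of pyrrolidin-2-yl on a saturated chain carbon bound to a nitrogen on an aromatic ring. Compound 2 with 50% and compound 3 with 67% also carry a six-membered aromatic ring of carbon only at that place, and both exceed compound 1. A rise beyond the scatter is therefore expected, with a step of about a number 16 percentage points higher from compound 1 to compound 4 (beyond the scatter). Compound 4 is estimated at 50%, within a range from 25% to 75%.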

Compound 4, a percentage reported as inhibition, at one concentration (the size of the read-out at that concentration, not a potency): 24%
Compound 4: middle estimate off by 26 percentage points, on the high side; measured number below the stated range.
By their numbers in this assay, from the lowest: compounds 4 and 1 (each within the scatter of the next); then compound 2; then compound 3.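

In this assay, swapping the saturated ring for an aromatic one gives a number 10 percentage points lower from compound 1 to compound 4 (within the scatter), so pyrrolidin-2-yl and 3-aminophenyl cannot be told apart at this place. An aromatic ring of carbon only on this saturated chain carbon therefore does not by itself raise the read-out, and the substituents it carries may matter. No measurement available here offers an explanation for this result.

Going by these compounds, it remains open what a plain phenyl ring, with no amine, would give at this place. On these data alone, a carboxylic acid in place of the amine on the ring is equally open.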